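Swapping Ethoxy for an Isopentenyl-Type Amino Group

A few compounds are considered here, and "the series" means these few. Any claim that something is new, unique, unknown or untested is made for them only; others in the source may bear on it.

Measured in a functional assay on HEp-2 cells (Homo sapiens) for inhibition; a lower number here means that less compound is needed, a higher number that more compound is needed for the effect:
- Compound 1 `CSc1ncnc2c1nnn2[C@@H]1O[C@H](CO)[C@@H](O)[C@H]1O`: 0.02 uM
- Compound 2 `COc1ncnc2c1nnn2[C@@H]1O[C@H](CO)[C@@H](O)[C@H]1O`: 0.3 uM
- Compound 3 `CCOc1ncnc2c1nnn2[C@@H]1O[C@H](CO)[C@@H](O)[C@H]1O`: 0.1 uM

Compound 3 stands in the middle of these numbers, between compound 1 and compound 2. Compound 4 `CC(C)=CCNc1ncnc2c1nnn2[C@@H]1O[C@H](CO)[C@@H](O)[C@H]1O` carries (3-methylbut-2-en-1-yl)amino in place of ethoxy on an aromatic carbon.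

Among the measured compounds shown here, three measured steps bear on this change. Exchanging the group on that carbon gave a 15-fold higher number from compound 1 to compound 2 (1.18 log units; beyond the scatter) and a 5.0-fold higher number from compound 1 to compound 3 (0.70 log units; beyond the scatter), while lengthening the chain gave a 3.0-fold lower number from compound 2 to compound 3 (0.48 log units; beyond the scatter). None of them involves an amino group, so the guidance is loose. A modest step toward a higher number is expected, given the sensitivity shown by a 5.0-fold higher number from compound 1 to compound 3 (0.70 log units; beyond the scatter). The estimated change is a 4.0-fold higher number from compound 3 to compound 4 (0.60 log units; beyond the scatter). For compound 4 the expected value is 0.4 uM, with an estimated range of 0.05 uM to 3 uM.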

Compound 4, concentration for half-maximal effect: < 3 uM
Compound 4 ended at the assay's limit; the forecaster's own chance of this, stated with the estimate: 10%; the middle value is on the limit's open side.
By their numbers in this assay, from the lowest: compound 1; then compound 3; then compound 2.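

In this assay, among the compounds shown here, compound 4 gave < 3 uM, which is a limit of the assay and not a number, so no step to it from compound 1, compound 2 or compound 3 can be read. The compounds shown leave open where compound 4 truly lies relative to those three.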